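A Urea Cut Back to a Simple Amide

This account rests on a few compounds, and the source may have more. Where it says the series, first, only, none or still open, it means among the compounds named here.

Measured so far in a functional assay on MDA-MB-435 cells (Homo sapiens) for inhibition, read by sulforhodamine B assay, with a stated time of 48 h; on this read-out lower numbers stand for stronger inhibition and higher numbers for weaker inhibition:
compound 1, `O=C(Nc1cccc(-n2cc(-c3ccncc3)c(-c3ccc(Cl)c(O)c3)n2)c1)Nc1ccc(Cl)c(Cl)c1`: 1100 nM
compound 2, `O=C(Nc1cccc(-n2cc(-c3ccncc3)c(-c3ccc(Cl)c(O)c3)n2)c1)Nc1cc(C(F)(F)F)cc(C(F)(F)F)c1`: 910 nM
compound 3, `COc1cc(-c2nn(-c3cccc(NC(=O)Nc4cccc(C(F)(F)F)c4)c3)cc2-c2ccncc2)ccc1Cl`: 870 nM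

In this assay compound 3 carries the lowest of the three numbers, yet compound 2 and compound 1 both lie within the usual scatter of it, so no order among the three can be read from these data. Compound 4, `COc1cc(-c2nn(-c3cccc(NC(=O)c4ccccc4)c3)cc2-c2ccncc2)ccc1Cl`, has not been measured. It differs from compound 3 in one place: phenyl in place of (3-(trifluoromethyl)phenyl)amino on a carbonyl carbon. Going by the values given here, no measured pair shows a change of this kind, so its effect in this assay is unknown. The expected step in this assay is a 2.9-fold higher number from compound 3 to compound 4 (0.46 log units; beyond the scatter), toward a higher number, beyond the scatter. Compound 4 is therefore estimated at 2500 nM, with a range from 900 nM to 7000 nM.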

Compound 4, half-maximal inhibitory concentration: 190 nM
Estimate against measurement, compound 4: 13-fold (1.12 log units) above; the measured number lies below the stated range.
By their numbers in this assay, from the lowest: compound 4; then compounds 3, 2 and 1 (each within the scatter of the next).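

With phenyl in place of (3-(trifluoromethyl)phenyl)amino on the carbonyl carbon, this assay shows a 4.6-fold lower number from compound 3 to compound 4 (0.66 log units; beyond the scatter) in favour of the simple amide, so the urea and its larger aryl group are not required for inhibition of these cells. That single step removes the amino nitrogen and the trifluoromethyl together, and the two cannot be separated here. No measurement bears on why the number fell. Still open, from the compounds shown here alone, is whether trifluoromethyl, an amine or a carboxylic acid on this phenyl would keep the gain, or whether a longer chain could replace the ring.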